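Swapping a Phenethyl for 3,5-Dichlorophenyl

This account rests on a few compounds, and the source may have more. Where it says the series, first, only, none or still open, it means among the compounds named here.

Of the compounds shown here, three sharing a core have been tested in an assay for inhibition of 3-hydroxy-3-methylglutaryl-coenzyme A reductase (Rattus norvegicus); on this read-out lower numbers stand for stronger inhibition and higher numbers for weaker inhibition. Compound 1 `O=C1C[C@H](O)C[C@@H](/C=C/c2c(Cl)cc(Cl)cc2CCc2ccccc2)O1` gives 430 nM. Compound 2 `CO[C@H]1CC(=O)O[C@H](/C=C/c2c(C)cc(C)cc2-c2ccc(F)c(C)c2)C1` gives 106 nM, and compound 3 `O=C1C[C@H](O)C[C@@H](/C=C/c2c(F)cc(F)cc2-c2ccc(F)cc2)O1` gives 860 nM. Among these three numbers compound 1 stands second highest: its number and that of compound 3 lie within the usual scatter of each other, while compound 2 sits clearly below it, beyond the scatter. The next compound, compound 4 `O=C1C[C@H](O)C[C@@H](/C=C/c2c(Cl)cc(Cl)cc2-c2cc(Cl)cc(Cl)c2)O1`, differs from compound 1 in one place: 3,5-dichlorophenyl in place of phenethyl on an aromatic carbon. Among the measured compounds shown here, no measured pair shows this same change, so the data give no direction for it. Compound 4 is expected to give 300 nM, within a range from 80 nM to 1200 nM. The step of a 1.4-fold lower number from compound 1 to compound 4 (0.16 log units; within the scatter) is expected to stay within the scatter, in no clear direction.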

Compound 4, half-maximal inhibitory concentration: 37 nM
The estimate for compound 4 lay 8.1-fold (0.91 log units) above the measured number; measured number below the stated range.
By their numbers in this assay, from the lowest: compound 4; then compound 2; then compounds 1 and 3 (each within the scatter of the next).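

In this assay, this position proves sensitive to the group it carries: 3,5-dichlorophenyl in place of phenethyl brings a 12-fold lower number from compound 1 to compound 4 (1.07 log units; beyond the scatter), the first clear effect of a single change in this set. The leaving and entering groups match in heavy-atom count and hydrogen-bond donors and acceptors, so these counts do not separate them. No measurement shown here accounts for the size of this step.

The change removes the two-carbon link and adds two chloro groups together, leaving their separate contributions open. A plain phenyl or a 3,5-dichlorophenethyl group here would help separate them.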